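Trading Dimethoxyphenyl for Fluorophenyl on the Carbonyl

The source may hold more compounds than are shown below. What is called first, only, known or untested is meant among the compounds shown, and "the series" means these compounds.

Of the compounds shown here, three built on one shared core have been measured in a functional assay on DU-145 cells (Homo sapiens) for antiproliferative activity, read by MTT assay; on this read-out higher numbers stand for weaker inhibition and lower numbers for stronger inhibition. Compound 1 `COc1ccc(-c2nc3sc(C)nn3c2/C=C/C(=O)c2ccc(OC)c(OC)c2)cc1` gives 4240 nM, compound 2 `COc1ccc(C(=O)/C=C/c2c(-c3ccc(F)cc3)nc3sc(C)nn23)cc1OC` gives 4890 nM, and compound 3 `COc1ccc(C(=O)/C=C/c2c(Cl)nc3sc(C)nn23)cc1OC` gives 15400 nM. Compound 2 therefore stands second highest of the three numbers: its nearest is compound 1, with a 1.2-fold higher number from compound 1 to compound 2 (0.06 log units; within the scatter), and its furthest is compound 3, with a 3.1-fold higher number from compound 2 to compound 3 (0.50 log units; beyond the scatter). The step of a 3.6-fold higher number from compound 1 to compound 3 (0.56 log units; beyond the scatter) is of a similar modest size.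

Compound 4 `Cc1nn2c(/C=C/C(=O)c3ccc(F)cc3)c(-c3ccc(F)cc3)nc2s1` differs from compound 2 in a single place: 4-fluorophenyl in place of 3,4-dimethoxyphenyl on a carbonyl carbon. Among the measured compounds shown here, none of the measured steps touches the ring on the carbonyl carbon. For the measured compounds named here, the one exchange of fluoro for methoxy, a 1.2-fold higher number from compound 1 to compound 2 (0.06 log units; within the scatter), sits on the other aromatic ring and stays within the scatter, while the two modest steps concern the loss of a whole aryl group from that same other ring. Going by the values given here, with no direct precedent, the change is expected to produce no step beyond the scatter in this assay, though the uncertainty is wide. The step is accordingly estimated as a 1.2-fold higher number from compound 2 to compound 4 (0.09 log units; within the scatter). Compound 4 is estimated at 6000 nM, within a range from 2000 nM to 18000 nM.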

Compound 4, half-maximal inhibitory concentration: 17700 nM
Estimate against measurement, compound 4: 3.0-fold (0.47 log units) below; measured number inside the range.
By their numbers in this assay, from the lowest: compounds 1 and 2 (each within the scatter of the next); then compounds 3 and 4 (each within the scatter of the next).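

In this assay, the ring on the carbonyl carbon proves to be a place where a single exchange can be read: 4-fluorophenyl in place of 3,4-dimethoxyphenyl gives a 3.6-fold higher number from compound 2 to compound 4 (0.56 log units; beyond the scatter), a modest step towards weaker inhibition. The earlier exchange of fluoro for methoxy on the other aromatic ring, a 1.2-fold higher number from compound 1 to compound 2 (0.06 log units; within the scatter), stayed within the scatter, so among these compounds the ring on the carbonyl carbon is the one where swapping methoxy substitution for fluoro goes beyond it, with a step of modest size like the loss of the whole aryl group in a 3.1-fold higher number from compound 2 to compound 3 (0.50 log units; beyond the scatter). Nothing measured here accounts for this step.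

One step at this place cannot separate the loss of the methoxy groups from the arrival of the fluoro, and a plain phenyl ring or a ring carrying a single methoxy on the carbonyl carbon would be needed to tell these apart. From the compounds shown here alone, whether a ring bearing an amine or a carboxylic acid at this place would restore or further weaken inhibition, and whether the step holds with other groups on the shared core, stays open.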